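Stripping the methoxy from a side chain at the limit

A few compounds are considered here, and "the series" means these few. Any claim that something is new, unique, unknown or untested is made for them only; others in the source may bear on it.

Measured so far:
- Compound 1 `OCCc1cn(Cc2ccc(Cl)cc2)c2ccccc12`: > 31600 nM
- Compound 2 `COCc1cn(Cc2ccc(Cl)cc2)c2ccccc12`: > 31600 nM

In an ADME assay on T29 cells (Homo sapiens) for cytotoxicity, read by sulforhodamine B assay, with a stated time of 3 days (on this read-out lower numbers stand for stronger inhibition and higher numbers for weaker inhibition), compound 1 reaches only a limit, > 31600 nM. Compound 2 likewise stands only at a limit, > 31600 nM. For the measured compounds named here, the series so far sits at the limit of > 31600 nM in this assay, at which 2 of the 2 values shown sit. Compound 3 `Cc1cn(Cc2ccc(Cl)cc2)c2ccccc12` differs from compound 2 by hydrogen in place of methoxy on a saturated chain carbon bound to an aromatic carbon. Going by the values given here, the one measured step at this place, a step that the two limits leave unreadable from compound 1 to compound 2, offers no size to carry over. The expected change in this assay is therefore a number no higher from compound 2 to compound 3 (the limit leaves the size open), none beyond the scatter, and another limit is likely. Compound 3 is expected near 31600 nM, with an estimated range of 12000 nM to 60000 nM.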

Compound 3, half-maximal inhibitory concentration: > 31600 nM
Compound 3: no number, only a limit (the forecaster's own chance of this, stated with the estimate: 75%); the middle value sits exactly at the limit.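

For the compounds shown here, compound 3, like compound 1 and compound 2, gives only a limit, so no step among them can be read. The compounds shown leave open whether changing this side chain alters the read-out at all: the limit of > 31600 nM in this assay, at which 3 of the 3 values shown sit.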